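A few compounds are considered here, and "the series" means these few. Any claim that something is new, unique, unknown or untested is made for them only; others in the source may bear on it.

Compound 2 `CC(O)(C(=O)Nc1ccc(S(=O)(=O)c2ccccc2)c(Cl)c1)C(F)(F)F` gives the lower of the two numbers measured in a functional assay (Cavia porcellus) with sulfonylurea receptors; K-ATP channels (Homo sapiens) as the target (on this read-out higher numbers stand for weaker inhibition and lower numbers for stronger inhibition), at 2200 nM. Compound 1 `CC(O)(C(=O)Nc1ccc(S(=O)(=O)c2cccc(F)c2)cc1)C(F)(F)F` stands nearest to it in this assay, at 3400 nM, a gap that falls within the usual scatter of the measurement, so the two cannot be ranked. Compound 3 `CC(O)(C(=O)Nc1ccc(S(=O)(=O)c2ccccc2)c([N+](=O)[O-])c1)C(F)(F)F` differs from compound 2 in one place: nitro in place of chloro on an aromatic carbon. No step of this kind has been measured among these compounds, so the size of the change is open. The step expected is no change at the digits printed from compound 2 to compound 3 (within the scatter), which means no movement beyond the scatter. Compound 3 is estimated at 2200 nM, between 700 nM and 7000 nM.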

Compound 3, half-maximal inhibitory concentration: > 30000 nM
Compound 3 gave a limit, no number (the forecaster's own chance of this, stated with the estimate: 5%); middle value at least 13-fold (1.13 log units) away from the limit.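

In this assay, the group at this position on the aromatic ring matters a great deal: nitro in place of chloro gives an at least 13-fold higher number from compound 2 to compound 3 (1.13 log units; beyond the scatter). On these data alone, for compound 3, > 30000 nM is a limit of the assay and not a number, so the full size of this step stays unknown. A single change at this position is thus enough to weaken inhibition far beyond the scatter.

As far as these compounds go, whether the same happens only with nitro stays open. A methyl, an amine or a nitrile at this position could show whether other groups are tolerated.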